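This account rests on a few compounds, and the source may have more. Where it says the series, first, only, none or still open, it means among the compounds named here.

Compound 1 `O=C(Nc1ccc(I)cc1)Nn1c(-c2ccccc2)nc2ccccc2c1=O` serves as the reference among the three measured compounds. In a functional assay on the whole organism (strain albino) with Mus musculus as the target, at a dose of 100 mg/kg by the intraperitoneal route (a higher number here means more inhibition at the dose given (going by the name of the read-out), a lower number less inhibition), compound 1 gives 60%, the highest of the three numbers, although within the scatter of compound 2 `O=C(Nc1ccc(F)cc1)Nn1c(-c2ccccc2)nc2ccccc2c1=O` with 54% and of compound 3 `Cc1ccccc1NC(=O)Nn1c(-c2ccccc2)nc2ccccc2c1=O` with 59%. The steps of a number 6 percentage points lower from compound 1 to compound 2 (within the scatter) and a number 1 percentage points lower from compound 1 to compound 3 (within the scatter), like a number 5 percentage points higher from compound 2 to compound 3 (within the scatter), all vary the aryl group on the amide-type nitrogen and stay within the scatter. Compound 4 `CCc1nc2ccccc2c(=O)n1NC(=O)Nc1ccc(I)cc1` alters the shared core instead: ethyl in place of phenyl on an aromatic carbon. Within the data shown here, no measured step touches this position, so the three measured steps give no direct guidance; they only show the series so far sitting in a narrow band. The expected step is therefore small, estimated as a number 5 percentage points lower from compound 1 to compound 4 (within the scatter). The estimate for compound 4 is 55%, in the range 35% to 72%.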

Compound 4, a percentage reported as inhibition, in the whole organism at one dose (the size of the read-out at that dose, not a potency): 55%
Compound 4: the middle estimate sits on the measured number at the digits printed; low and high end bracket the measured number.
By their numbers in this assay, from the lowest: compounds 2, 4, 3 and 1 (each within the scatter of the next).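

With ethyl in place of phenyl on the aromatic carbon between two ring nitrogen atoms, this assay shows a number 5 percentage points lower from compound 1 to compound 4 (within the scatter). This is the only step shown that touches the shared core, and at this one dose an aromatic ring at this position is not needed to stay within the scatter of compound 1. No measured evidence bears on the reason for this result. Still open, from the compounds shown here alone, is whether an amine or a longer chain such as butyl at this position stays within the scatter of compound 4. Also open, going by these compounds, is whether ethyl gives the same result with 4-fluorophenyl or 2-methylphenyl on the amide-type nitrogen.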